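From 4-fluoropiperidin-1-yl to piperazin-1-yl on a shared core

The source may report more compounds than this note shows. Statements on the series, on what has been measured and on what is new or still open speak of the compounds shown alone.

In a physicochemical assay for solubility, measured as kinetic solubility (on this read-out lower numbers stand for lower solubility and higher numbers for higher solubility), compound 1 (`O=C(Nc1cccc(Cl)c1)c1cc(C(F)(F)F)ccc1OCc1ccccc1`) gives 7000 nM as its reading. Compound 2 (`O=C(Nc1ccnnc1)c1cc(N2CCC(F)CC2)ccc1OCc1ccccc1`) gives 20000 nM and holds the higher of the two numbers, with its gap to compound 1 beyond the usual scatter. Compound 3 (`O=C(Nc1ccnnc1)c1cc(N2CCNCC2)ccc1OCc1ccccc1`) has not yet been measured. It carries piperazin-1-yl in place of 4-fluoropiperidin-1-yl on an aromatic carbon, para to the benzyloxy group and meta to the (pyridazin-4-yl)carbamoyl group. Among the measured compounds shown here, no pair of measured compounds differs in one place only, so the data offer no direct guide to this change. On the structural change alone, a rise beyond the scatter is expected in this assay as a moderate step. The estimate for this swap is a change (a 2.5-fold higher number from compound 2 to compound 3 (0.40 log units; beyond the scatter)) upward. Compound 3 is expected at 50000 nM (estimated range 18000 nM to 130000 nM).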

Compound 3, solubility: 98000 nM
Compound 3: middle estimate off by 2.0-fold (0.29 log units), on the low side, within the range that was stated.
By their numbers in this assay, from the lowest: compound 1; then compound 2; then compound 3.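

In this assay, this position, para to the benzyloxy group and meta to the (pyridazin-4-yl)carbamoyl group, now has its first comparison in one place: piperazin-1-yl in place of 4-fluoropiperidin-1-yl gives a 4.9-fold higher number from compound 2 to compound 3 (0.69 log units; beyond the scatter) on the shared core. Among the compounds shown here, the earlier pair differed in more than one place, so this is the first sign that the ring at this position alone can move the read-out beyond the usual scatter. No measurement at hand explains the rise. Going by these compounds, it remains open whether morpholin-4-yl or 4-methylpiperazin-1-yl at the same carbon would give a similar step, which would help separate the role of the free ring amine from that of the ring as a whole. On these data alone, whether the step carries over with another amide group also remains open.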